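This account rests on a few compounds, and the source may have more. Where it says the series, first, only, none or still open, it means among the compounds named here.

In a functional assay on M21 cells (Homo sapiens) for cytotoxicity, read by sulforhodamine B assay, with a stated time of 48 h (on this read-out higher numbers stand for weaker inhibition and lower numbers for stronger inhibition), compound 1 `CCc1ccccc1NS(=O)(=O)c1ccc(NC(=O)NCCCCl)cc1` reports only a limit, > 200000 nM. Compound 2 `CCCc1ccccc1NS(=O)(=O)c1ccc(NC(=O)NCCCCl)cc1` gives 38000 nM. The change between them is methyl in place of hydrogen on a saturated chain carbon, two bonds along the chain from an aromatic carbon, and the step it made is an at least 5.2-fold lower number from compound 1 to compound 2 (0.72 log units; beyond the scatter), which rests on (the limit of > 200000 nM in this assay, at which 1 of the 3 values shown sits). Compound 3 `CCNC(=O)Nc1cccc(S(=O)(=O)Nc2ccccc2CC)c1` likewise reports only a limit in this assay, > 100000 nM, as seen in the limit of > 100000 nM in this assay, at which 1 of the 3 values shown sits. How the core of compound 3 differs from the core of compound 1 is not broken down here. Compound 4 `CCCc1ccccc1NS(=O)(=O)c1cccc(NC(=O)NCC)c1` carries the same change relative to compound 3, namely (methyl in place of hydrogen on a saturated chain carbon, two bonds along the chain from an aromatic carbon). Given that the measured step of an at least 5.2-fold lower number from compound 1 to compound 2 (0.72 log units; beyond the scatter) was at least modest, the step expected for compound 4 is an at least 2.5-fold lower number from compound 3 to compound 4 (0.39 log units; beyond the scatter). The estimated value for compound 4 is 40000 nM, between 10000 nM and 200000 nM.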

Compound 4, half-maximal inhibitory concentration: 60000 nM
Compound 4: the middle estimate sits 1.5-fold (0.18 log units) below what was measured; the measured number falls inside the stated range.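

On the core of compound 3, the change from ethyl to propyl gives an at least 1.6-fold lower number from compound 3 to compound 4 (0.22 log units; that floor lies within the scatter). This agrees in direction with the lower number seen on the core of compound 1, but that floor alone does not show a real gain. Both steps start from a compound that reports only a limit, so neither step has a known true size, and it cannot be said whether the change carries over to the same extent: the same change on two cores in this assay, an at least 5.2-fold lower number (0.72 log units; beyond the scatter) from compound 1 to compound 2 and an at least 1.6-fold lower number (0.22 log units; that floor lies within the scatter) from compound 3 to compound 4; the limit leaves it open whether they differ

The compounds shown leave open whether a longer chain, such as butyl, would lower the number further on either core. They also leave open whether a branched chain, such as isopropyl, would act as propyl does.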